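This account rests on a few compounds, and the source may have more. Where it says the series, first, only, none or still open, it means among the compounds named here.

Compound 1 `Fc1ccc(C2CC(c3ccc(Cl)s3)=NN2c2nc(-c3ccc(Cl)cc3)cs2)cc1` is the reference point of this small set. In a functional assay on A549 cells (Homo sapiens) for antiproliferative activity, read by XTT assay, with a stated time of 24 h (a higher number here means a weaker inhibitor, a lower number a stronger inhibitor), compound 1 gives 125 ug/mL, the only outright number among the three results shown. Compound 2 `CS(=O)(=O)c1ccc(-c2csc(N3N=C(c4ccc(Cl)s4)CC3c3ccc(F)cc3)n2)cc1` carries methylsulfonyl in place of chloro on an aromatic carbon. In this assay compound 2 reaches only a limit of the assay, > 500 ug/mL. Compound 3 `COc1ccc(-c2csc(N3N=C(c4ccc(Cl)s4)CC3c3ccc(F)cc3)n2)cc1`, with methoxy in place of chloro on an aromatic carbon, likewise stops at a limit. In this assay compound 3 gives > 500 ug/mL. The steps read an at least 4.0-fold higher number from compound 1 to compound 2 (0.60 log units; beyond the scatter) and an at least 4.0-fold higher number from compound 1 to compound 3 (0.60 log units; beyond the scatter), while a step that the two limits leave unreadable from compound 2 to compound 3 because of the limit of > 500 ug/mL in this assay, at which 2 of the 3 values shown sit.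

Compound 4 `Cc1ccc(C2=NN(c3nc(-c4ccc(Cl)cc4)cs3)C(c3ccc(F)cc3)C2)s1` differs from compound 1 at another place: methyl in place of chloro on an aromatic carbon. Neither measured step touches the chloro of the five-membered aromatic ring with 1 sulfur; both exchange a different chloro on an aromatic carbon, and both weaken the inhibitor by at least a modest amount. Within the data shown here, with no closer precedent, compound 4 is expected to stay near compound 1, with a 1.2-fold higher number from compound 1 to compound 4 (0.08 log units; within the scatter) falling within the usual scatter or only a little beyond it. Compound 4 is therefore estimated at 150 ug/mL, between 60 ug/mL and 400 ug/mL.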

Compound 4, half-maximal inhibitory concentration: > 500 ug/mL
Compound 4 ended at the assay's limit (the forecaster's own chance of this, stated with the estimate: 20%); middle value at least 3.3-fold (0.52 log units) from the limit.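

Among these compounds, replacing chloro with methyl on the aromatic carbon next to the ring sulfur, which turns 5-chlorothiophen-2-yl into 5-methylthiophen-2-yl, gives an at least 4.0-fold higher number from compound 1 to compound 4 (0.60 log units; beyond the scatter) in this assay, so this position responds too, not only the chloro exchanged in the earlier compounds. The change is small in what is counted, one heavy atom for one heavy atom with no hydrogen-bond donor or acceptor on either side, and it still carries the result from an outright number to a limit of the assay. Among the compounds shown, all three replacements of a chloro, at either of the two places, end at that limit, and none goes against this.

On these data alone, the size of the loss for compound 4 and any order among compound 2, compound 3 and compound 4 cannot be read: the limit of > 500 ug/mL in this assay, at which 3 of the 4 values shown sit. Whether another group on this ring carbon, such as bromo, ethyl, an amine or a carboxylic acid, would keep an outright number in this assay stays open, as does whether the chloro itself is needed here or only some group other than methyl.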